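A pyrazine in place of a methylfuran on the core

A few compounds are considered here, and "the series" means these few. Any claim that something is new, unique, unknown or untested is made for them only; others in the source may bear on it.

Compound 1 `c1coc(-c2ccccc2NCC2=NCCN2)c1`: 16.2 nM in a functional assay for activation of Alpha-1D adrenergic receptor (Homo sapiens); on this read-out lower numbers stand for an effect already at smaller amounts and higher numbers for an effect only at larger amounts of compound.
Compound 2 `Cc1ccc(-c2ccccc2NCC2=NCCN2)o1`: < 2000 nM, a limit of this assay.

Compound 2 stands at a limit only, < 2000 nM. The step that the limit leaves unreadable from compound 1 to compound 2 cannot be sized because it ends at the limit of < 2000 nM in this assay, at which 1 of the 2 values shown sits. Compound 3 `c1ccc(-c2cnccn2)c(NCC2=NCCN2)c1` differs from compound 2 by pyrazin-2-yl in place of 5-methylfuran-2-yl on an aromatic carbon. No readable step bears on this change, so the expectation rests on the shared core and on compound 1, which in this assay gives 16.2 nM. Compound 3 is therefore expected near 150 nM, with a range from 15 nM to 2000 nM. For compound 3 the estimated step is a step that the limit leaves unreadable from compound 2 to compound 3.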

Compound 3, half-maximal effective concentration: 182 nM
Compound 3: middle estimate off by 1.2-fold (0.08 log units), on the low side; the range from low to high includes it.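

In this assay, for the compounds shown here, pyrazin-2-yl in place of furan-2-yl on this aromatic carbon gives an 11-fold higher number from compound 1 to compound 3 (1.05 log units; beyond the scatter), which is the first readable size for a change at this position. The methyl and methylfuran comparisons add no size, since compound 2 gives only a limit and both steps touching it cannot be read: the limit of < 2000 nM in this assay, at which 1 of the 3 values shown sits. From the compounds shown here alone, whether the higher number follows from the ring size or from the added ring nitrogen stays open, and thiophen-2-yl or pyridin-2-yl in this place would separate the two.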